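Second Methoxy Group Added: Expected Effect on Cell Toxicity

A few compounds are considered here, and "the series" means these few. Any claim that something is new, unique, unknown or untested is made for them only; others in the source may bear on it.

In a functional assay on PC-12 cells (Rattus norvegicus) for cytotoxicity, read by MTT assay, with stated times of 3 h and 2 h, tested at 5 uM (a lower number here means a weaker effect, a higher number a stronger effect of the compound at the concentration tested), compound 1 `O=C(CCCCC1CCSS1)NCc1cn(CCCCOc2ccc3cc(-c4ccccc4)c(=O)oc3c2)nn1` gives 32.8%, compound 2 `COc1ccc(-c2cc3ccc(OCCCCn4cc(CNC(=O)CCCCC5CCSS5)nn4)cc3oc2=O)cc1` gives 44.9% and compound 3 `COc1ccc(-c2cc3ccc(OCCCCCn4cc(CNC(=O)CCCCC5CCSS5)nn4)cc3oc2=O)cc1` gives 41%. Compound 2 arises from compound 1 by methoxy in place of hydrogen on an aromatic carbon, a change that produced a number 12.1 percentage points higher from compound 1 to compound 2 (beyond the scatter). How the core of compound 3 differs from that of compound 1 is not broken down here. Compound 4 `COc1ccc(-c2cc3ccc(OCCCCCn4cc(CNC(=O)CCCCC5CCSS5)nn4)cc3oc2=O)cc1OC` has not yet been measured; it differs from compound 3 by methoxy in place of hydrogen on an aromatic carbon. Among the measured compounds shown here, this is the same kind of change as the one from compound 1 to compound 2, but not the same: there the new group sat para to a large group, here it sits ortho to a methoxy group and meta to a large group. Because the earlier step was a number 12.1 percentage points higher from compound 1 to compound 2 (beyond the scatter), a somewhat smaller rise is expected, estimated as a number 6 percentage points higher from compound 3 to compound 4 (within the scatter). Compound 4 is therefore expected to give about 47%, with a likely range from 36% to 58%.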

Compound 4, a percentage reported as activity, at one concentration (the size of the read-out at that concentration, not a potency): 46.9%
Compound 4: the middle estimate sits 0.1 percentage points above what was measured; the range from low to high includes it.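

In this assay, going from 4-methoxyphenyl to 3,4-dimethoxyphenyl gives a number 5.9 percentage points higher from compound 3 to compound 4 (within the scatter), so this step alone cannot be told apart from repeat-to-repeat variation. Set beside the matching step on the other core, the two sizes cannot be told apart either: the same change on two cores in this assay, a number 12.1 percentage points higher (beyond the scatter) from compound 1 to compound 2 and a number 5.9 percentage points higher (within the scatter) from compound 3 to compound 4, 6.2 percentage points apart, within the scatter of two such steps This fits the change carrying over between these cores but does not prove it, since there are only two steps, the new methoxy group does not sit in the same place in both, and only one step lies beyond the scatter.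

The compounds shown leave open whether an amine or a carboxylic acid in that place would act like a methoxy group. They also leave open how a longer chain than that of compound 4 would alter the read-out.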